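Chain length and chromone core in an ileum antagonist series

The compounds below may be only part of what the source reports. "The series", "measured", "known", "first", "only" and "open" are said of these compounds alone.

Measured so far:
compound 1, `O=C(O)c1cc(=O)c2ccc(OCCCCCOc3ccccc3)cc2o1`, 0.4 ug/mL
compound 2, `O=C(O)c1cc(=O)c2ccc(OCCCCCCCOc3ccccc3)cc2o1`, 1.8 ug/mL
compound 3, `O=C(O)c1cc(=O)c2cccc(OCCCOc3ccccc3)c2o1`, 50 ug/mL

In a functional assay on ileum (Cavia porcellus) for antagonist activity, with a stated time of 30 s (a higher number here means a weaker inhibitor, a lower number a stronger inhibitor), compound 1 gives 0.4 ug/mL, and compound 2, which carries a longer chain, gives 1.8 ug/mL; the change is 2-phenoxyethyl in place of phenoxy on a saturated chain carbon, five bonds along the chain from an oxygen on an aromatic ring, and the step is a 4.5-fold higher number from compound 1 to compound 2 (0.65 log units; beyond the scatter). Compound 3, built on a different core, gives 50 ug/mL in this assay, the highest of the three numbers. The difference between the two cores is not broken down here. Compound 4, `O=C(O)c1cc(=O)c2cccc(OCCCCCOc3ccccc3)c2o1`, is not yet measured in this assay. It arises from compound 3 by 2-phenoxyethyl in place of phenoxy on a saturated chain carbon, three bonds along the chain from an oxygen on an aromatic ring, the same kind of change as from compound 1 to compound 2, though here the place is three bonds along the chain from the ring oxygen rather than five. If the lengthening acts on compound 3 as it did on compound 1, the step from compound 3 to compound 4 is expected to be a 2.4-fold higher number from compound 3 to compound 4 (0.38 log units; beyond the scatter). Compound 4 is therefore estimated to give 120 ug/mL, with a plausible range from 25 ug/mL to 500 ug/mL.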

Compound 4, half-maximal inhibitory concentration: 9 ug/mL
The estimate for compound 4 lay 13-fold (1.12 log units) above the measured number, and the stated range ends above it.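

In this assay putting 2-phenoxyethyl in place of phenoxy gives a 5.6-fold lower number from compound 3 to compound 4 (0.74 log units; beyond the scatter) on this core, so here the longer chain goes with the stronger inhibitor. The same change ran the opposite way on the core of compound 1, and the two steps differ by more than the usual scatter: the same change on two cores in this assay, a 4.5-fold higher number (0.65 log units; beyond the scatter) from compound 1 to compound 2 and a 5.6-fold lower number (0.74 log units; beyond the scatter) from compound 3 to compound 4, 25-fold (1.40 log units) apart, beyond the scatter of two such steps

This change therefore cannot be carried from one core to the other as a fixed step, although two pairs do not show why the direction reverses or how it would run on a third core.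

Still open, as far as these compounds go, is whether a longer chain on the core of compound 4 would strengthen inhibition further or weaken it. Also open, from the compounds shown here alone, is how an amine in the chain would behave on either core.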